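Isopropyl for methyl on the sulfur of compound 1

This account rests on a few compounds, and the source may have more. Where it says the series, first, only, none or still open, it means among the compounds named here.

In a functional assay on MV4-11 cells (Homo sapiens) for inhibition, read by resazurin assay, with a stated time of 72 h (a lower number here means a stronger inhibitor of growth, a higher number a weaker inhibitor of growth), compound 1 `COc1ccc(Nc2nccc(-c3sc(SC)nc3C)n2)c(OC)c1` gives 530 nM and compound 3 `Oc1ccccc1Nc1nccc(-c2c[nH]c3ccccc23)n1` gives 570 nM, two values within the scatter of each other. Compound 2 `COc1ccc(Nc2nccc(-c3c[nH]c4ccccc34)n2)c(OC(F)F)c1` gives 4770 nM. The gap between compound 1 and compound 2 lies beyond the scatter. Compound 4 `COc1ccc(Nc2nccc(-c3sc(SC(C)C)nc3C)n2)c(OC)c1` has isopropyl in place of methyl on a sulfur, whose other neighbour is an aromatic carbon (isopropyl in place of methyl on a sulfur). Among the measured compounds shown here, no measured pair isolates a change at this sulfur, so the expectation rests on compound 1 at 530 nM and the size of the change. In this assay, a small loss of growth inhibition is expected, with the estimated step of a 1.3-fold higher number from compound 1 to compound 4 (0.12 log units; within the scatter). Compound 4 is estimated at 700 nM, with an expected range of 250 nM to 2000 nM.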

Compound 4, concentration for 50% growth inhibition: 5670 nM
The estimate for compound 4 lay 8.1-fold (0.91 log units) below the measured number; measured number above the stated range.
By their numbers in this assay, from the lowest: compounds 1 and 3 (each within the scatter of the next); then compounds 2 and 4 (each within the scatter of the next).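

In this assay, among the compounds shown here, isopropyl in place of methyl on the sulfur gives an 11-fold higher number from compound 1 to compound 4 (1.03 log units; beyond the scatter) and is the first measured pair that isolates a change at this position. Growth inhibition therefore depends strongly on the group on this sulfur, and methylsulfanyl is clearly preferred over isopropylsulfanyl here. Nothing at hand accounts for the size of this step.

As far as these compounds go, whether ethyl on this sulfur stays near compound 1 or falls toward compound 4 remains open. So does the outcome with a hydroxyethyl chain or a free amine at the same place.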